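Carbamate alkene lactones: bromo to ethyl on the aryl ring

The source may report more compounds than this note shows. Statements on the series, on what has been measured and on what is new or still open speak of the compounds shown alone.

Within the data shown here, compound 2 `C=C1C(=O)OC[C@H]1CCOC(=O)Nc1ccc(Br)cc1` gives 350 nM in a functional assay on RAW264.7 cells (Mus musculus) for inhibition, with a stated time of 30 min (on this read-out lower numbers stand for stronger inhibition and higher numbers for weaker inhibition), and holds the lowest of the two numbers measured so far; its nearest neighbour is compound 1 `C=C1C(=O)OC[C@H]1CCOC(=O)Nc1ccc(CCCC)cc1`, which gives 620 nM in this assay, a gap within the scatter. Among the measured compounds shown here, the one step measured, a 1.8-fold lower number from compound 1 to compound 2 (0.25 log units; within the scatter), is the only guide for the aryl substituent. Compound 3 `C=C1C(=O)OC[C@H]1CCOC(=O)Nc1ccc(CC)cc1` differs from compound 2 by ethyl in place of bromo on an aromatic carbon. Ethyl is a short chain, shorter than the butyl of compound 1 and larger than the bromo of compound 2, and the butyl-to-bromo step stayed within the scatter, so no change beyond the scatter is expected for compound 3 in this assay. The expected step is a 1.3-fold higher number from compound 2 to compound 3 (0.11 log units; within the scatter), essentially flat. Compound 3 is estimated at 450 nM in this assay, with a range from 200 nM to 1000 nM.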

Compound 3, half-maximal inhibitory concentration: 840 nM
The estimate for compound 3 lay 1.9-fold (0.27 log units) below the measured number; the range from low to high includes it.
By their numbers in this assay, from the lowest: compounds 2, 1 and 3 (each within the scatter of the next, the first and the last beyond it).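

In this assay, the aryl position now gives a step beyond the scatter, though a modest one, with ethyl in place of bromo (a 2.4-fold higher number from compound 2 to compound 3 (0.38 log units; beyond the scatter)), which the butyl-to-bromo step had not shown. The two alkyl chains stay within the scatter of each other (a 1.4-fold higher number from compound 1 to compound 3 (0.13 log units; within the scatter)), so among these compounds bromo is separated beyond the scatter from ethyl only, and not from butyl. Nothing at hand explains the difference between bromo and ethyl.

From the compounds shown here alone, whether this separation belongs to bromo alone or extends to other halogens, such as chloro or fluoro, remains open. Also open, going by these compounds, is how the read-out responds at this place to a group of another kind, such as an amine or a carboxylic acid, or to a chain longer than butyl.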